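A few compounds are considered here, and "the series" means these few. Any claim that something is new, unique, unknown or untested is made for them only; others in the source may bear on it.

Measured so far in a toxicity assay on the whole organism (strain Icem-CET (SPF Caw)) for cytotoxicity, with Mus musculus as the target; on this read-out lower numbers stand for an effect already at smaller amounts and higher numbers for an effect only at larger amounts of compound:
compound 1 `C=CCNC(=O)/C(C)=C(/C)c1ccc(OC)cc1`: 280 mg/kg
compound 2 `C=CCNC(=O)/C(C)=C(\C)c1ccc(Br)cc1`: 120 mg/kg
compound 3 `C=CCNC(=O)/C(C)=C(\C)c1ccccc1`: 130 mg/kg

Compound 3 sits close to compound 2 in this assay; the two numbers lie within the scatter of each other. Compound 1 stands apart from both with the higher number, and the gap from compound 3 to compound 1 is beyond the scatter. Within the data shown here, the only single-point step among the measured compounds is a 1.1-fold higher number from compound 2 to compound 3 (0.03 log units; within the scatter), which is within the scatter.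

Compound 4 `C=CCNC(=O)/C(C)=C(\C)c1ccc(OC)cc1` differs from compound 3 by methoxy in place of hydrogen on an aromatic carbon. Among the measured compounds shown here, no measured step covers this change with the same double-bond geometry. Compound 1 carries the same methoxy group but the other geometry of the double bond, and compound 1 gives 280 mg/kg, whereas compound 3 gives 130 mg/kg. Taking that comparison as the closest guide, with the caveat of the geometry, a shift toward a higher number is expected, a 1.5-fold higher number from compound 3 to compound 4 (0.19 log units; within the scatter), though the bearing of the geometry on this assay is unknown. Compound 4 is estimated at 200 mg/kg, within 110 mg/kg to 380 mg/kg.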

Compound 4, dose for half-maximal effect: 200 mg/kg
The estimate for compound 4 equals the measured number at the digits printed; the range from low to high includes it.
By their numbers in this assay, from the lowest: compounds 2, 3, 4 and 1 (each within the scatter of the next, the first and the last beyond it).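

In this assay, methoxy on the aromatic carbon para to a large group now has a reading with the double-bond geometry held constant (a 1.5-fold higher number from compound 3 to compound 4 (0.19 log units; within the scatter)). The replacement of bromo at the same position also stays within the scatter (a 1.7-fold higher number from compound 2 to compound 4 (0.22 log units; within the scatter)), so hydrogen, bromo and methoxy at this position cannot be told apart in this series. Double-bond geometry also gets its first direct reading, again within the scatter (a 1.4-fold lower number from compound 1 to compound 4 (0.15 log units; within the scatter)), from a single pair that isolates this one element: (the fact that compounds 1 and 4 differ only in the configuration as drawn).

From the compounds shown here alone, whether the geometry step stays within the scatter with hydrogen or bromo at this position remains open. Also open, going by these compounds, is whether an amine or a carboxylic acid at this position, or a longer chain on the amide nitrogen, would move the number beyond the scatter.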